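Moving the bromine on compound 2

The compounds below may be only part of what the source reports. "The series", "measured", "known", "first", "only" and "open" are said of these compounds alone.

Compound 1 `OC[C@H]1O[C@@H](n2cnc3c(NCc4ccc(F)cc4)ncnc32)[C@H](O)[C@@H]1O`: > 166000 nM, a limit
Compound 2 `OC[C@H]1O[C@@H](n2cnc3c(NCc4cccc(Br)c4)ncnc32)[C@H](O)[C@@H]1O`: > 166000 nM, a limit

In a functional assay on G-361 cells (Homo sapiens) for antiproliferative activity, with a stated time of 72 h (a lower number here means a stronger inhibitor, a higher number a weaker inhibitor), compound 2 gives > 166000 nM, which is a limit and not a number. Both measured compounds stand there: the limit of > 166000 nM in this assay, at which 2 of the 2 values shown sit. Going by the values given here, the one measured step, a step that the two limits leave unreadable from compound 1 to compound 2, changed the aryl group and shows no readable size, so it offers no sign of a gain. Compound 3 `OC[C@H]1O[C@@H](n2cnc3c(NCc4ccc(Br)cc4)ncnc32)[C@H](O)[C@@H]1O` has 4-bromophenyl in place of 3-bromophenyl on a saturated chain carbon bound to a nitrogen on an aromatic ring. The expected change is a step that the limit leaves unreadable from compound 2 to compound 3, with no step beyond the scatter expected in this assay. For compound 3 the estimated value is 170000 nM, within 80000 nM to 300000 nM.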

Compound 3, half-maximal inhibitory concentration: > 166000 nM
Compound 3 was reported as a limit; the forecaster's own chance of this, stated with the estimate: 85%; the middle value lies beyond the limit too.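

Compound 3 gives a limit and not a number, like compound 1 and compound 2, so no step among them can be read: the limit of > 166000 nM in this assay, at which 3 of the 3 values shown sit.

From the compounds shown here alone, how strongly any of the three compounds acts in this assay, and whether 3-bromophenyl and 4-bromophenyl differ there, stays open.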